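Ethylurea Replacing Pivalamide in an Aryl Sulfonate Series

This account rests on a few compounds, and the source may have more. Where it says the series, first, only, none or still open, it means among the compounds named here.

Compound 1, `CC(=O)Nc1ccc(S(=O)(=O)Oc2ccccc2C(C)C)cc1`: 16000 nM
Compound 2, `CC(C)c1ccccc1OS(=O)(=O)c1ccc(NC(=O)C(C)(C)C)cc1`: 6500 nM
Compound 3, `CC(C)(C)C(=O)Nc1ccc(S(=O)(=O)Oc2ccccc2I)cc1`: 6600 nM

In a functional assay on MCF7 cells (Homo sapiens) for antiproliferative activity, read by sulforhodamine B assay, with a stated time of 48 h (on this read-out higher numbers stand for weaker inhibition and lower numbers for stronger inhibition), compound 2 holds the lowest number of the three measured. One neighbouring step stays within the scatter: a 1.0-fold higher number from compound 2 to compound 3 (0.01 log units; within the scatter). The other does not: a 2.5-fold lower number from compound 1 to compound 2 (0.39 log units; beyond the scatter), tert-butyl in place of methyl on the carbonyl carbon.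

Compound 4, `CCNC(=O)Nc1ccc(S(=O)(=O)Oc2ccccc2C(C)C)cc1`, differs from compound 2 by ethylamino in place of tert-butyl on a carbonyl carbon. For the measured compounds named here, only the step from compound 1 to compound 2 bears on this carbonyl position, and it was modest. Ethylamino is neither the methyl of compound 1 nor the tert-butyl of compound 2, so compound 4 is expected to fall between them, giving a 1.5-fold higher number from compound 2 to compound 4 (0.19 log units; within the scatter). Compound 4 is therefore estimated at 10000 nM, with a range from 4000 nM to 25000 nM.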

Compound 4, half-maximal inhibitory concentration: 10000 nM
For compound 4 middle estimate and measured number coincide at the digits printed; measured number inside the range.
By their numbers in this assay, from the lowest: compounds 2, 3, 4 and 1 (each within the scatter of the next, the first and the last beyond it).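

In this assay, ethylamino on the carbonyl carbon brings a nitrogen and a hydrogen-bond donor that tert-butyl and methyl lack, yet both steps stay within the scatter: a 1.5-fold higher number from compound 2 to compound 4 (0.19 log units; within the scatter) and a 1.6-fold lower number from compound 1 to compound 4 (0.20 log units; within the scatter) are the two readings. Compound 4 therefore cannot be told apart from compound 1 or compound 2, even though those two lie beyond the scatter of each other. No available evidence explains this result. The compounds shown leave open how a longer chain or a dimethylamino group would read at this carbonyl carbon. They also leave open whether ethylamino would read the same with iodo in place of isopropyl.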